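Amide aryl variation on a shared biaryl aminoquinoline core

The source may report more compounds than this note shows. Statements on the series, on what has been measured and on what is new or still open speak of the compounds shown alone.

The compounds share one core and differ only in the aryl group attached to the carbonyl carbon of the amide. Compound 1 `COc1ccc(C(=O)Nc2cccc(-c3ccnc4c(N)cccc34)c2)cc1OC` carries a 3,4-dimethoxyphenyl there and gives 9500 nM in a functional assay on A375P cells (Homo sapiens) for antiproliferative activity, read by MTT assay, with a stated time of 48 h; on this read-out lower numbers stand for stronger inhibition and higher numbers for weaker inhibition. Compound 2 `Cc1ccc(C(=O)Nc2cccc(-c3ccnc4c(N)cccc34)c2)cc1C` carries a 3,4-dimethylphenyl; in this assay compound 2 reaches only a limit, > 20000 nM, namely (the limit of > 20000 nM in this assay, at which 1 of the 3 values shown sits). Compound 3 `Nc1cccc2c(-c3cccc(NC(=O)c4cccc(C(F)(F)F)c4)c3)ccnc12` carries a 3-(trifluoromethyl)phenyl and gives 7900 nM in this assay. The measured steps are an at least 2.1-fold higher number from compound 1 to compound 2 (0.32 log units; beyond the scatter), a 1.2-fold lower number from compound 1 to compound 3 (0.08 log units; within the scatter) and an at least 2.5-fold lower number from compound 2 to compound 3 (0.40 log units; beyond the scatter). Compound 3 thus provides the lower of the two numbers given, though compound 1 sits within the scatter of it; the third value is a limit.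

Compound 4 `Nc1cccc2c(-c3cccc(NC(=O)c4ccc5c(c4)OCCO5)c3)ccnc12` is the next variation at the same place: 2,3-dihydro-1,4-benzodioxin-6-yl in place of 3-(trifluoromethyl)phenyl on a carbonyl carbon. All three measured steps are aryl replacements on the carbonyl carbon and bear on it. For the measured compounds named here, only the step away from 3,4-dimethylphenyl moved the number beyond the scatter, whereas the exchange between 3,4-dimethoxyphenyl and 3-(trifluoromethyl)phenyl, a 1.2-fold lower number from compound 1 to compound 3 (0.08 log units; within the scatter), stayed within it. For compound 4 no step beyond the scatter is therefore expected in this assay, in either direction. The expected step is a 1.1-fold higher number from compound 3 to compound 4 (0.06 log units; within the scatter). Compound 4 is estimated at 9000 nM, with a range of 4000 nM to 20000 nM.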

Compound 4, half-maximal inhibitory concentration: 860 nM
Compound 4: the middle estimate sits 10-fold (1.02 log units) above what was measured, and the stated range ends above it.
By their numbers in this assay, from the lowest: compound 4; then compounds 3 and 1 (each within the scatter of the next). At a limit, above all of these: compound 2.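

The position on the carbonyl carbon can move the number well beyond the scatter in this assay, which the exchange of 3,4-dimethoxyphenyl for 3-(trifluoromethyl)phenyl did not show: a 9.2-fold lower number from compound 3 to compound 4 (0.96 log units; beyond the scatter), and an 11-fold lower number from compound 1 to compound 4 (1.04 log units; beyond the scatter). Oxygen on the aryl group is not enough to explain this, since compound 1 also carries oxygen yet lies within the scatter of compound 3, which has none, so the gain in this set goes with the closed 2,3-dihydro-1,4-benzodioxin-6-yl ring and not with the open 3,4-dimethoxyphenyl. The remaining step, an at least 23-fold lower number from compound 2 to compound 4 (1.36 log units; beyond the scatter), rests on a limit and not on a number: the limit of > 20000 nM in this assay, at which 1 of the 4 values shown sits.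

The compounds shown do not separate the role of the ring oxygens from that of the closed non-aromatic ring itself, a question that an indane ring, with carbon in their place, or a methylenedioxy ring, with a smaller closed ring, would bear on. Also open, as far as these compounds go, is whether an amine or a carboxylic acid on the aryl group would keep or lose the number of compound 4, 860 nM.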